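This account rests on a few compounds, and the source may have more. Where it says the series, first, only, none or still open, it means among the compounds named here.

Three compounds share one core and differ only in the group attached to one aromatic carbon. Compound 1 `COc1ccc(C2CC(c3ccccc3)=NN2C2=NC(=O)/C(=C3\C(=O)Nc4ccccc43)S2)cc1` carries a methoxy group there, and in a functional assay on cells (Cancer cell lines, Homo sapiens) for cytotoxicity, read by sulforhodamine B assay, with a stated time of 48 h (on this read-out higher numbers stand for weaker inhibition of growth and lower numbers for stronger inhibition of growth), compound 1 gives 3350 nM. Compound 2 `O=C1N=C(N2N=C(c3ccccc3)CC2c2ccc(Cl)cc2)S/C1=C1/C(=O)Nc2ccccc21` carries a chloro group, and in this assay compound 2 gives 850 nM. Compound 3 `CN(C)c1ccc(C2CC(c3ccccc3)=NN2C2=NC(=O)/C(=C3\C(=O)Nc4ccccc43)S2)cc1` carries a dimethylamino group, and in this assay compound 3 gives 34000 nM, the highest number of the three and thus the weakest growth inhibition. The measured steps are a 3.9-fold lower number from compound 1 to compound 2 (0.60 log units; beyond the scatter), a 10-fold higher number from compound 1 to compound 3 (1.01 log units; beyond the scatter) and a 40-fold higher number from compound 2 to compound 3 (1.60 log units; beyond the scatter).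

Compound 4 `CN(C)c1ccc(C2CC(c3ccccc3)=NN2C2=NC(=O)/C(=C3\C(=O)Nc4ccc(Cl)cc43)S2)cc1` keeps the dimethylamino group of compound 3 and adds (chloro in place of hydrogen on an aromatic carbon), on the part of the core that is a fused or bridged system of two rings. Within the data shown here, none of the measured steps touches that place; all three concern the other aromatic carbon, so they give no direct guide to the size or direction of this change. With nothing to anchor it, the expected step is small, a 1.5-fold lower number from compound 3 to compound 4 (0.19 log units; within the scatter), and the uncertainty is wide. Compound 4 is therefore estimated at 22000 nM in this assay, within a range from 5000 nM to 90000 nM.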

Compound 4, concentration for total growth inhibition: 690 nM
Compound 4: middle estimate off by 32-fold (1.50 log units), on the high side; the whole stated range lies above it.
By their numbers in this assay, from the lowest: compounds 4 and 2 (each within the scatter of the next); then compound 1; then compound 3.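

In this assay, among these compounds, putting chloro in place of hydrogen on the fused system of two rings gives a 49-fold lower number from compound 3 to compound 4 (1.69 log units; beyond the scatter), so this part of the core, untouched by the earlier steps, strongly affects the read-out. The weak growth inhibition of compound 3 is therefore not set by its dimethylamino group alone, since a single added chlorine elsewhere, with that group kept, brings the number down sharply. No measurement here explains why this one atom has so large an effect.

From the compounds shown here alone, this chloro appears only alongside the dimethylamino group, so whether it would lower the number as much with methoxy or chloro at the other aromatic carbon stays open. Also open, going by these compounds, is how other groups at this place, such as fluoro, methoxy or a carboxylic acid, would compare with chloro.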